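Cytotoxicity of a urea series: chlorine gives way to amine

The source may report more compounds than this note shows. Statements on the series, on what has been measured and on what is new or still open speak of the compounds shown alone.

Compound 2 `Cc1cc(NC(=O)Nc2ccc(Cl)cc2)c2ccccc2n1` carries a 4-chlorophenyl on an amide-type nitrogen whose other neighbour is a carbonyl carbon. In an ADME assay on BJ cells (Homo sapiens) for cytotoxicity, with a stated time of 72 h (on this read-out higher numbers stand for an effect only at larger amounts of compound and lower numbers for an effect already at smaller amounts), compound 2 gives only a limit, > 25000 nM. Its neighbour compound 1 `Cc1cc(NC(=O)Nc2ccc(O)cc2)c2ccccc2n1` likewise gives only a limit in this assay, > 25000 nM. Going by the values given here, the single measured step, a step that the two limits leave unreadable from compound 1 to compound 2, is therefore unreadable, since both values sit at the limit of > 25000 nM in this assay, at which 2 of the 2 values shown sit. Compound 3 `Cc1cc(NC(=O)Nc2ccccc2N)c2ccccc2n1` has not yet been measured; it differs from compound 2 by 2-aminophenyl in place of 4-chlorophenyl on an amide-type nitrogen. Among the compounds with values here, no measured step bears directly on this change, and the two known values both stop at the same limit. The expectation is that compound 3 again shows no effect within the tested range, so the step that the limit leaves unreadable from compound 2 to compound 3 is estimated to stay within the scatter. Compound 3 is therefore expected to give about 30000 nM in this assay, with a range from 12000 nM to 100000 nM.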

Compound 3, half-maximal effective concentration: > 25000 nM
Compound 3 ended at the assay's limit; the forecaster's own chance of this, stated with the estimate: 80%; the middle value is on the limit's open side.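

Going by these compounds alone, compound 1, compound 2 and compound 3 all end at a limit in this assay, so no step among them can be read: the limit of > 25000 nM in this assay, at which 3 of the 3 values shown sit. The compounds shown leave open where their actual values lie, and whether changing the group on the amide-type nitrogen alters cytotoxicity at all.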